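A few compounds are considered here, and "the series" means these few. Any claim that something is new, unique, unknown or untested is made for them only; others in the source may bear on it.

Compound 1, `CCCCCCc1ccc(NC(=O)N[C@H](C)c2ccccc2)cc1`, gives 100% in an ADME assay on the whole organism with Oryza sativa as the target, tested at 0.1 uM; a lower number here means a stronger effect, a higher number a weaker effect of the compound at the concentration tested.
Compound 2, `CCCCCCCc1ccc(NC(=O)N[C@H](C)c2ccccc2)cc1`, gives 100% in this assay.

Compound 2 stands level with compound 1 at the digits shown; the step of no change at the digits printed from compound 1 to compound 2 (within the scatter) lies within the scatter. Compound 3, `CC(=O)c1ccc(NC(=O)N[C@H](C)c2ccccc2)cc1`, differs from compound 2 by acetyl in place of heptyl on an aromatic carbon. Among the compounds with values here, no measured step concerns an acetyl entering in place of heptyl; the only step known, no change at the digits printed from compound 1 to compound 2 (within the scatter), was flat and offers little guidance, so the expectation rests on the value of compound 2 alone and carries a wide range. Compound 3 is expected to give 90%, between 55% and 100%. The expected step is a number 10 percentage points lower from compound 2 to compound 3 (within the scatter).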

Compound 3, a percentage reported as activity, at one concentration (the size of the read-out at that concentration, not a potency): 96%
Compound 3: middle estimate off by 6 percentage points, on the low side, and the stated range covers the measured number.
By their numbers in this assay, from the lowest: compounds 3, 1 and 2 (each within the scatter of the next).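

The earlier pair varied only the length of the alkyl chain on this aromatic carbon, para to a large group. Here the chain gives way to acetyl, a smaller group with a carbonyl and a hydrogen-bond acceptor, and this assay shows a number 4 percentage points lower from compound 2 to compound 3 (within the scatter) and a number 4 percentage points lower from compound 1 to compound 3 (within the scatter), so even this change of group type stays within the scatter. Nothing measured bears on why this is so. On these data alone, whether an amine or a carboxylic acid on this carbon would move the number beyond the scatter remains open, as does the effect of any change elsewhere on the shared core.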